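Methoxy in Place of Iodo on a Level Series

The source may hold more compounds than are shown below. What is called first, only, known or untested is meant among the compounds shown, and "the series" means these compounds.

In a functional assay on A549 cells (Homo sapiens) for cytotoxicity, read by MTT assay (a lower number here means a stronger inhibitor, a higher number a weaker inhibitor), compound 1 `C=C1C(=O)[C@]23C[C@@]1(Cl)CC[C@H]2[C@@]12C=CC(=O)[C@](C)(C(=O)O1)[C@H]2[C@@H]3C(=O)OC` gives 60300 nM and compound 2 `C=C1C(=O)[C@]23C[C@@]1(I)CC[C@H]2[C@@]12C=CC(=O)[C@](C)(C(=O)O1)[C@H]2[C@@H]3C(=O)OC` gives 53200 nM while compound 3 `C=C1C(=O)[C@]23C[C@@]1(I)CC[C@H]2[C@@]12C=CC(=O)[C@](C)(C(=O)O1)[C@H]2[C@@H]3C(=O)OCc1ccccc1` gives 46000 nM and so stands level with both within the usual scatter. Compound 4 `C=C1C(=O)[C@]23C[C@@]1(OC)CC[C@H]2[C@@]12C=CC(=O)[C@](C)(C(=O)O1)[C@H]2[C@@H]3C(=O)OCc1ccccc1` differs from compound 3 by one change methoxy in place of iodo on a saturated ring carbon that puts methoxy in place of iodo on a saturated ring carbon. The nearest evidence is a 1.1-fold lower number from compound 1 to compound 2 (0.05 log units; within the scatter) for iodo in place of chloro on a saturated ring carbon. Adding phenyl elsewhere gave a 1.2-fold lower number from compound 2 to compound 3 (0.06 log units; within the scatter) and also stayed within the scatter. Going by the values given here, no measured compound carries methoxy, so these are weak guides, and no step beyond the scatter is expected in this assay here. The estimated step of a 1.1-fold higher number from compound 3 to compound 4 (0.04 log units; within the scatter) stays within that scatter. Compound 4 is expected at 50000 nM with a likely range from 25000 nM to 100000 nM as the estimate.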

Compound 4, half-maximal inhibitory concentration: 28200 nM
The estimate for compound 4 lay 1.8-fold (0.25 log units) above the measured number; the measured number falls inside the stated range.
By their numbers in this assay, from the lowest: compounds 4, 3, 2 and 1 (each within the scatter of the next, the first and the last beyond it).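

Compounds 1 to 3 carry only chloro or iodo on this saturated ring carbon, while compound 4 carries methoxy, which brings one hydrogen-bond acceptor. In this assay this change gives a 1.6-fold lower number from compound 3 to compound 4 (0.21 log units; within the scatter) and so leaves the compounds level, showing that a group joined through oxygen can stand here in place of a halogen without a step beyond the scatter. Nothing measured here speaks to the reason for this result. Still open, going by these compounds, is whether an amine, a carboxylic acid or a longer chain such as butoxy on this carbon would stay level too.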